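This account rests on a few compounds, and the source may have more. Where it says the series, first, only, none or still open, it means among the compounds named here.

Three compounds share one core and differ only in the acid-bearing group attached to an aromatic carbon. In a functional assay on HFL1 cells for antagonist activity at sphingosine 1-phosphate receptor 2 (Homo sapiens), read by ELISA, with a stated time of 24 h, in the presence of a further agent that is not named here (on this read-out lower numbers stand for stronger inhibition and higher numbers for weaker inhibition), compound 1 `O=C(O)Cc1nn(Cc2cn3cc(OCC4CC4)c(Cl)cc3n2)c2ccccc2c1=O` gives 60 nM, compound 2 `O=C(O)C1(c2nn(Cc3cn4cc(OCC5CC5)c(Cl)cc4n3)c3ccccc3c2=O)CC1` gives 304 nM, and compound 3 `CC(C)(C(=O)O)c1nn(Cc2cn3cc(OCC4CC4)c(Cl)cc3n2)c2ccccc2c1=O` gives 361 nM. Compound 3 stands furthest from compound 1, since a 6.0-fold higher number from compound 1 to compound 3 (0.78 log units; beyond the scatter), whereas a 1.2-fold higher number from compound 2 to compound 3 (0.07 log units; within the scatter). Compound 4 `CCC(C(=O)O)c1nn(Cc2cn3cc(OCC4CC4)c(Cl)cc3n2)c2ccccc2c1=O` carries one change: 1-carboxypropyl in place of 1-carboxy-1-methylethyl on an aromatic carbon. Among the compounds with values here, the steps that bear on this are a 5.1-fold higher number from compound 1 to compound 2 (0.70 log units; beyond the scatter) and a 6.0-fold higher number from compound 1 to compound 3 (0.78 log units; beyond the scatter), both modest, and a 1.2-fold higher number from compound 2 to compound 3 (0.07 log units; within the scatter), which was flat. Compound 4 is estimated at 160 nM, with a range from 60 nM to 450 nM. In this assay that would mean an expected 2.3-fold lower number from compound 3 to compound 4 (0.35 log units; beyond the scatter).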

Compound 4, half-maximal inhibitory concentration: 25 nM
Compound 4: middle estimate off by 6.4-fold (0.81 log units), on the high side, and the stated range ends above it.
By their numbers in this assay, from the lowest: compound 4; then compound 1; then compounds 2 and 3 (each within the scatter of the next).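

Putting 1-carboxypropyl in place of 1-carboxy-1-methylethyl gives a 14-fold lower number from compound 3 to compound 4 (1.16 log units; beyond the scatter) even though the two groups have the same atoms joined differently, so at this position the arrangement of the chain matters, not just its atom count. Against 1-carboxycyclopropyl, the same group gives a 12-fold lower number from compound 2 to compound 4 (1.08 log units; beyond the scatter) as well. Both earlier branched groups had raised the number from compound 1, yet ethyl in place of hydrogen on the saturated chain carbon gives a 2.4-fold lower number from compound 1 to compound 4 (0.38 log units; beyond the scatter) and so shows that a substituent there can also lower it.

Going by these compounds, whether 1-carboxyethyl or a longer chain such as 1-carboxybutyl would go lower still remains open. Nothing available here explains these differences.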